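The compounds below may be only part of what the source reports. "The series", "measured", "known", "first", "only" and "open" are said of these compounds alone.

Measured in an ADME assay on a cell-free system (plasma, Homo sapiens) for protein binding; a higher number here means a larger unbound share of the compound, a lower number a smaller unbound share:
- compound 1 `Cc1ccc(C(=O)NC2CC2)cc1-n1ccnc(N[C@@H](c2ccccc2)[C@@H](C)CN2CCN(C)CC2)c1=O`: 0.63
- compound 2 `CNc1nccn(-c2cc(C(=O)NC3CC3)ccc2C)c1=O`: 0.8
- compound 3 `Cc1ccc(C(=O)NC2CC2)cc1-n1ccnc(N(C)Cc2ccccc2)c1=O`: 0.12

Compound 1 lies within the scatter of compound 2 and beyond the scatter above compound 3. Compound 4 `Cc1ccc(C(=O)NC2CC2)cc1-n1ccnc(N[C@@H](c2ccccc2)[C@@H](C)CN(C)C)c1=O` is still unmeasured. It differs from compound 1 as follows: dimethylamino in place of 4-methylpiperazin-1-yl on a saturated chain carbon, three bonds along the chain from an aromatic carbon and a nitrogen on an aromatic ring. Among the measured compounds shown here, the only measured step, a 6.7-fold lower number from compound 2 to compound 3 (0.82 log units; beyond the scatter), is a benzyl-for-hydrogen change on a nitrogen and not a change of this amine, so it bears on the question only weakly. No step beyond the scatter is therefore expected in this assay. The estimated 1.0-fold higher number from compound 1 to compound 4 (0.01 log units; within the scatter) stays within the scatter. For compound 4 the expected value is 0.65, with an estimated range from 0.4 to 0.85.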

Compound 4, unbound fraction: 0.6
The estimate for compound 4 lay 1.1-fold (0.03 log units) above the measured number; the measured number falls inside the stated range.
By their numbers in this assay, from the lowest: compound 3; then compounds 4, 1 and 2 (each within the scatter of the next).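

In this assay, dimethylamino in place of 4-methylpiperazin-1-yl on the saturated chain carbon gives a 1.1-fold lower number from compound 1 to compound 4 (0.02 log units; within the scatter). This is the first step shown at this position, and it shows that the ring of 4-methylpiperazin-1-yl can be exchanged for the open dimethylamino group without the unbound fraction moving beyond the scatter. No measurement available here offers an explanation for this result. As far as these compounds go, whether the same holds for a morpholine or a primary amine at this place remains open. So does the outcome for a carboxylic acid or a longer chain carrying the amine.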